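Series notes: from iodo to methoxy at compound 4

This account rests on a few compounds, and the source may have more. Where it says the series, first, only, none or still open, it means among the compounds named here.

Compound 1 `COc1cccc(-c2nn(-c3ccccc3)cc2C(Nc2nc3ccccc3s2)c2c(O)ccc3ccccc23)c1` gives 16900 nM
Compound 2 `COc1ccc2nc(NC(c3cn(-c4ccccc4)nc3-c3cccc([N+](=O)[O-])c3)c3c(O)ccc4ccccc34)sc2c1` gives 26800 nM
Compound 3 `COc1ccc2nc(NC(c3cn(-c4ccccc4)nc3-c3cccc(I)c3)c3c(O)ccc4ccccc34)sc2c1` gives 20000 nM

In a functional assay on MCF7 cells (Homo sapiens) for antiproliferative activity, read by MTT assay, with a stated time of 48 h (a higher number here means a weaker inhibitor, a lower number a stronger inhibitor), compound 3 gives 20000 nM and lies within the scatter of both compound 1 and compound 2. The change to compound 4 `COc1cccc(-c2nn(-c3ccccc3)cc2C(Nc2nc3ccc(OC)cc3s2)c2c(O)ccc3ccccc23)c1` is methoxy in place of iodo on an aromatic carbon. Going by the values given here, the one measured step at this place, a 1.3-fold lower number from compound 2 to compound 3 (0.13 log units; within the scatter), is small. Compound 1 with its 3-methoxyphenyl group gives 16900 nM in the same narrow band. No step beyond the scatter is therefore expected in this assay, and the estimated change is a 1.1-fold lower number from compound 3 to compound 4 (0.02 log units; within the scatter). For compound 4 the expected value is 19000 nM, with an estimated range from 10000 nM to 36000 nM.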

Compound 4, half-maximal inhibitory concentration: 62600 nM
Estimate against measurement, compound 4: 3.3-fold (0.52 log units) below, and the stated range ends below it.
By their numbers in this assay, from the lowest: compounds 1, 3 and 2 (each within the scatter of the next); then compound 4.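

Of the groups on this aromatic carbon, iodo and nitro sat within the scatter of each other, whereas 3-methoxyphenyl separates from both: a 3.1-fold higher number from compound 3 to compound 4 (0.50 log units; beyond the scatter) and a 2.3-fold higher number from compound 2 to compound 4 (0.37 log units; beyond the scatter). The 3-methoxyphenyl group alone does not set this level, since compound 1 carries it too, and methoxy in place of hydrogen elsewhere on the core gives a 3.7-fold higher number from compound 1 to compound 4 (0.57 log units; beyond the scatter). Nothing available explains these steps.

Still open, going by these compounds, is whether an amine or a carboxylic acid on this carbon would track with iodo and nitro or with methoxy. Also open, on these data alone, is how 3-iodophenyl behaves with hydrogen in place of the second methoxy.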